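A few compounds are considered here, and "the series" means these few. Any claim that something is new, unique, unknown or untested is made for them only; others in the source may bear on it.

Going by the values given here, in a functional assay on SEM cells (Homo sapiens) for antiproliferative activity, with a stated time of 72 h (on this read-out higher numbers stand for an effect only at larger amounts of compound and lower numbers for an effect already at smaller amounts), compound 1 `C=CCNC(=O)n1c(-c2ccc(OC)cc2)cc(=O)c2c(OC)cc(OC)cc21` gives 12000 nM, the only exact number so far. Compound 2 `COc1cc(OC)c2c(=O)cc(C(=O)Nc3ccc(N4CCN(C)CC4)cc3)[nH]c2c1` is reported only as a limit, > 19800 nM, and is not a measured number. Its position is therefore known only as the limit of > 19800 nM in this assay, at which 1 of the 2 values shown sits.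

Compound 3 `COc1cc(OC)c2c(=O)cc(C(=O)Nc3ccc(-n4cccc4)cc3)[nH]c2c1` shares its core with compound 2 and differs in one place: 1H-pyrrol-1-yl in place of 4-methylpiperazin-1-yl on an aromatic carbon, para to a large group (1H-pyrrol-1-yl in place of 4-methylpiperazin-1-yl on an aromatic carbon). Among the compounds with values here, no measured pair shows what this swap does, so any expectation here is rough. It is expected to leave compound 3 in the same weak range as compound 1, which gives 12000 nM. The estimated change, an at least 1.9-fold lower number from compound 2 to compound 3 (0.29 log units; that floor lies within the scatter), is modest and points towards an effect at smaller amounts. For compound 3 the expected value is 10000 nM, with an estimated range of 3000 nM to 30000 nM.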

Compound 3, half-maximal effective concentration: > 77000 nM
Compound 3 was reported as a limit; the forecaster's own chance of this, stated with the estimate: 45%; middle value at least 7.7-fold (0.88 log units) away from the limit.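

Compound 2 and compound 3 are both reported only as limits in this assay, and the swap between them gives no readable step. The compounds shown leave open whether putting 1H-pyrrol-1-yl in place of 4-methylpiperazin-1-yl changes the antiproliferative effect at all, and in which direction.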